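The compounds below may be only part of what the source reports. "The series", "measured", "known", "first", "only" and "open" are said of these compounds alone.

Compound 3 `CCC1C(=O)N(C)c2cnc(Nc3ccc(S(=O)(=O)NCCCO)cc3)nc2N1c1ccn(C)n1` gives 21600 nM in a functional assay on MCF7 cells (Homo sapiens) for antiproliferative activity, read by CCK-8 assay, with a stated time of 72 h (on this read-out higher numbers stand for weaker inhibition of growth and lower numbers for stronger inhibition of growth), the highest of the three numbers recorded so far: compound 2 `CC[C@@H]1C(=O)N(C)c2cnc(Nc3ccc(S(=O)(=O)NC4CCCC4)cc3)nc2N1C1CCCC1` gives 688 nM and compound 1 `CC[C@@H]1C(=O)N(C)c2cnc(Nc3ccc(S(=O)(=O)NCCO)cc3)nc2N1C1CCCC1` gives 344 nM, both sitting far below it, beyond the scatter. Compound 4 `CCC1C(=O)N(C)c2cnc(Nc3ccc(S(=O)(=O)NCCO)cc3)nc2N1c1ccn(C)n1` differs from compound 3 by hydroxy in place of hydroxymethyl on a saturated chain carbon, two bonds along the chain from a sulfonamide nitrogen. For the measured compounds named here, no measured step touches this part of the chain. Going by the values given here, the only step at the sulfonamide nitrogen, a 2.0-fold higher number from compound 1 to compound 2 (0.30 log units; within the scatter), stayed within the scatter, and it swapped a whole substituent rather than shortening a chain by one carbon. A small change of this kind is therefore expected to move the number little, a 1.2-fold lower number from compound 3 to compound 4 (0.08 log units; within the scatter). Compound 4 is estimated at 18000 nM, between 7000 nM and 45000 nM.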

Compound 4, concentration for 50% growth inhibition: "not active" (no number reported)
The entry for compound 4 holds no number, so the estimate cannot be set against anything.
By their numbers in this assay, from the lowest: compounds 1 and 2 (each within the scatter of the next); then compound 3.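

For the compounds shown here, compound 4 is recorded only as not active, with no number, so no step from compound 3 to compound 4 can be read. Nothing shown here offers an explanation for this result. From the compounds shown here alone, how far changing 3-hydroxypropyl to 2-hydroxyethyl shifts growth inhibition remains open.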